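Moving from Pyridin-2-yl to Pyridin-4-yl on the Amide

The compounds below may be only part of what the source reports. "The series", "measured", "known", "first", "only" and "open" are said of these compounds alone.

Measured compounds:
- compound 1, `COc1cc2c(cc1OC)C(CC(=O)Nc1ccccc1C)CC2`: 23.3%
- compound 2, `COc1cc2c(cc1OC)C(CC(=O)Nc1ccccn1)CC2`: 33.3%

In a functional assay on the whole organism (strain Wistar) for inhibition, with Rattus norvegicus as the target, read by paw edema, with a stated time of 24 h, at a dose of 100 mg/kg (on this read-out higher numbers stand for more inhibition at the one dose given (going by the name of the read-out) and lower numbers for less inhibition), compound 2 gives 33.3%. Compound 1 gives 23.3%, and the step of a number 10 percentage points higher from compound 1 to compound 2 (within the scatter) shows that these two numbers lie within the scatter of each other, so the inhibition in this assay is level between the two.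

Compound 3, `COc1cc2c(cc1OC)C(CC(=O)Nc1ccncc1)CC2`, differs from compound 2 by pyridin-4-yl in place of pyridin-2-yl on an amide-type nitrogen. Among the measured compounds shown here, the only measured step, a number 10 percentage points higher from compound 1 to compound 2 (within the scatter), placed pyridin-2-yl in place of 2-methylphenyl and gave no change beyond the scatter; it says nothing about exchanging one pyridinyl group for another. Both measured numbers sit close together, and nothing in the data points to a change either way. The step of a number 3.3 percentage points lower from compound 2 to compound 3 (within the scatter) is therefore expected to stay within the scatter. Compound 3 is estimated at 30%, with a range from 10% to 50%.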

Compound 3, a percentage reported as inhibition, in the whole organism at one dose (the size of the read-out at that dose, not a potency): 46.7%
For compound 3 the middle estimate is 16.7 percentage points below the measured one; measured number inside the range.
By their numbers in this assay, from the lowest: compounds 1 and 2 (each within the scatter of the next); then compound 3.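

In this assay, putting pyridin-4-yl in place of pyridin-2-yl on the amide-type nitrogen gives a number 13.4 percentage points higher from compound 2 to compound 3 (beyond the scatter), so two groups with the same counted atoms can be told apart here, and how those atoms are joined matters at this position. Pyridin-4-yl in place of 2-methylphenyl gives a number 23.4 percentage points higher from compound 1 to compound 3 (beyond the scatter), a difference beyond the scatter that the earlier step between compound 1 and compound 2 did not show. Nothing given here explains why these groups differ.

Going by these compounds, whether pyridin-3-yl would sit closer to pyridin-2-yl or to pyridin-4-yl stays open, as does the effect of a phenyl ring carrying an amine or a carboxylic acid on this nitrogen. On these data alone, with a single dose and a single time in this assay, the compounds' relative potency also remains unknown.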